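Cyclopropyl for bromo on the shared core: solubility outlook

The source may report more compounds than this note shows. Statements on the series, on what has been measured and on what is new or still open speak of the compounds shown alone.

Two compounds of the series have numbers in a physicochemical assay for solubility, in phosphate buffer, measured as kinetic solubility, with a stated time of 24 h, at pH 7.4; a lower number here means a less soluble compound, a higher number a more soluble compound. Compound 1 `NS(=O)(=O)c1ccc(CNc2nc(Nc3cccc(NC(=O)N4CCCC4)c3)ncc2Br)cc1` gives 20000 nM. For the measured compounds named here, compound 2 `O=C(NCCCNc1nc(Nc2cccc(NC(=O)N3CCCC3)c2)ncc1Br)C1CCC1` gives 177000 nM, the higher of the two numbers, and the single measured step, an 8.9-fold higher number from compound 1 to compound 2 (0.95 log units; beyond the scatter), separates it from compound 1.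

Compound 3 `O=C(NCCCNc1nc(Nc2cccc(NC(=O)N3CCCC3)c2)ncc1C1CC1)C1CCC1` is not yet measured in this assay. It differs from compound 2 by cyclopropyl in place of bromo on an aromatic carbon, the change sitting on an aromatic carbon of a six-membered aromatic ring with 2 nitrogen, two atoms from the ring nitrogen.

Going by the values given here, no measured step bears on this change: the only step on record, from compound 1 to compound 2, alters the substituent on the saturated chain carbon and leaves the bromo untouched in both compounds. Without a comparable pair, the expectation for compound 3 rests on compound 2 alone, and no step beyond the scatter is expected, a 1.2-fold lower number from compound 2 to compound 3 (0.07 log units; within the scatter). On that basis compound 3 is estimated at 150000 nM in this assay, in the range 50000 nM to 400000 nM, with the range kept broad for lack of a relevant precedent.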

Compound 3, solubility: 164000 nM
Beside the measured number, compound 3's estimate is 1.1-fold (0.04 log units) below it; measured number inside the range.
By their numbers in this assay, from the lowest: compound 1; then compounds 3 and 2 (each within the scatter of the next).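

Notes on the series: cyclopropyl in place of bromo gives the first direct reading at this aromatic carbon of the six-membered aromatic ring with 2 nitrogen, and in this assay the change amounts to a 1.1-fold lower number from compound 2 to compound 3 (0.03 log units; within the scatter). On this single pair, the exchange of one bromine atom for a cyclopropyl of 3 heavy atoms, with its three-membered non-aromatic ring, leaves compound 2 and compound 3 indistinguishable in this read-out, so the bromo is not required to keep the number of compound 2 with this cyclobutylcarbonyl-bearing chain. No supporting measurement is available to explain why the two compounds read alike.

Still open, going by these compounds, is how a group of a different kind on the same aromatic carbon, such as a nitrile, an amine or a carboxylic acid, would read in this assay. Also open, on these data alone, is whether cyclopropyl in place of bromo gives the same outcome alongside the 4-sulfamoylphenyl substituent of compound 1, since a single pair cannot show whether the result carries over to other chains.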